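Decylthio Compound 4: Estimating Cytotoxicity Without a Measured Step

The compounds below may be only part of what the source reports. "The series", "measured", "known", "first", "only" and "open" are said of these compounds alone.

Measured in an ADME assay on Vero cells (Chlorocebus sabaeus) for cytotoxicity (a higher number here means that more compound is tolerated, a lower number that less compound is tolerated), so far:
compound 1 `CCCCCCCCCCSc1ncnc2c1ncn2C1CCCC1` gives 8.04 ug/mL
compound 2 `CCCCCCCCCCSc1nc(N)nc2c1ncn2CC(=O)N[C@H](C)C(=O)OC` gives "not determined" (no result reported)
compound 3 `CCCCCCCCCCSc1nc(NC(C)=O)nc2[nH]cnc12` gives "not determined" (no result reported)

Compound 2 has no place on the numeric scale, since no single result was reported for it. Compound 3 is likewise without a number. The series therefore offers one figure, which is the result for compound 1 at 8.04 ug/mL in this series.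

A single change defines the next compound, which is compound 4 `CCCCCCCCCCSc1nc(N)nc2c1ncn2CC` and has no value yet. In words, methyl takes the place of (1-(methoxycarbonyl)ethyl)carbamoyl on a saturated chain carbon bound to an aromatic nitrogen, and the full tally reads methyl in place of (1-(methoxycarbonyl)ethyl)carbamoyl on a saturated chain carbon bound to an aromatic nitrogen as counted from the two structures.

Going by the values given here, no measured step exists to show what such a change does, and the missing result for compound 2 leaves no starting point from which to give a direction. The expectation is therefore modest: compound 4 should land near the one measured figure, with no difference beyond the usual scatter, and the range has to stay wide on so little evidence. The estimate for compound 4 is 9 ug/mL in this assay, expected to fall between 3.5 ug/mL and 25 ug/mL on measurement.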

Compound 4, half-maximal cytotoxic concentration: 12.3 ug/mL
Compound 4: the middle estimate sits 1.4-fold (0.14 log units) below what was measured; the measured number falls inside the stated range.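

In this assay, going by these compounds alone, compound 4 gives 12.3 ug/mL and compound 2 has no single number to set against it, so no step between them can be read. The compounds shown leave open how exchanging (1-(methoxycarbonyl)ethyl)carbamoyl for methyl shifts the result in this assay and whether it shifts at all. Nothing available explains the value of compound 4.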